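A Methyl Added on the Way from Compound 2 to Compound 3

The source may hold more compounds than are shown below. What is called first, only, known or untested is meant among the compounds shown, and "the series" means these compounds.

Measured so far:
compound 1, `O=C(NO)c1ccc(/C=C/c2ccc(O)cc2)o1`: 86400 nM
compound 2, `O=C(/C=C/c1ccc(/C=C/C(=O)c2ccccc2)o1)NO`: 20200 nM

Both compounds were tested in a functional assay on A549 cells (Homo sapiens) for antiproliferative activity, read by MTT assay, with a stated time of 48 h; a higher number here means a weaker inhibitor, a lower number a stronger inhibitor. Of the two numbers, compound 2 gives the lower one, which means the stronger inhibition; compound 1 gives a higher number, and that gap lies beyond the usual scatter of repeated measurements. The two structures differ in several places at once, so the measured pair alone does not show which part of the change carries the gap.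

Compound 3, `Cc1ccc(C(=O)/C=C/c2ccc(/C=C/C(=O)NO)o2)cc1`, has not yet been measured. It differs from compound 2 in one place only: methyl in place of hydrogen on an aromatic carbon. For the measured compounds named here, no measured pair in this set shows what such a change does, so the expectation rests on the value of compound 2 and on the small size of the change. The step of a 1.3-fold lower number from compound 2 to compound 3 (0.10 log units; within the scatter) is expected to be small, within the scatter, with no clear direction. For compound 3 the expected value in this assay is therefore 16000 nM, with a range from 6000 nM to 45000 nM.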

Compound 3, half-maximal inhibitory concentration: 48600 nM
Estimate against measurement, compound 3: 3.0-fold (0.48 log units) below, and the stated range ends below it.
By their numbers in this assay, from the lowest: compound 2; then compounds 3 and 1 (each within the scatter of the next).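

In this assay, for the compounds shown here, going from phenyl to 4-methylphenyl gives a 2.4-fold higher number from compound 2 to compound 3 (0.38 log units; beyond the scatter), the first comparison in this set in which only one place changes. It shows that this position, on the six-membered aromatic ring and para to a large group, does not accept even one added carbon without a cost: the step is modest, but it lies beyond the scatter and points towards weaker inhibition. The earlier pair of compound 1 and compound 2 could not show this, since those two structures differ in several places at once, and no available evidence accounts for the step. With only methyl and hydrogen compared at this position, one step cannot show whether any added group here raises the number or whether the result is particular to methyl. A fluorine atom, a methoxy group, an amine, a carboxylic acid or a longer chain such as ethyl in the same place would each test that question, and the same methyl at another carbon of the ring would show how far the effect depends on its position.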